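Working notes: ethyl to propyl, compound 2 to compound 3

The source may report more compounds than this note shows. Statements on the series, on what has been measured and on what is new or still open speak of the compounds shown alone.

- compound 1 `O=C(O)c1cc(N2C(=O)C3=C(CCCC3)C2=O)ccc1Cl`: > 100000 nM
- compound 2 `CCOC(=O)c1cc(N2C(=O)C3=C(CCCC3)C2=O)ccc1Cl`: 1910 nM

In a functional assay on the whole organism for inhibition, with Scenedesmus acutus as the target (on this read-out lower numbers stand for stronger inhibition and higher numbers for weaker inhibition), compound 1 gives only a limit, > 100000 nM. Going by the values given here, compound 2, at 1910 nM, holds the only actual number. Compound 3 `CCCOC(=O)c1cc(N2C(=O)C3=C(CCCC3)C2=O)ccc1Cl` differs from it by methyl in place of hydrogen on a saturated chain carbon, two bonds along the chain from an oxygen next to a carbonyl group: ethyl to propyl, methyl in place of hydrogen on a saturated chain carbon, two bonds along the chain from an oxygen next to a carbonyl group. Among the compounds with values here, the one measured step that bears on this, an at least 52-fold lower number from compound 1 to compound 2 (1.71 log units; beyond the scatter), is large, but it puts a whole ethyl in place of hydrogen on that oxygen. Only one more methyl enters here, so no comparable change is expected. The expected change in this assay is a 1.5-fold lower number from compound 2 to compound 3 (0.17 log units; within the scatter), slightly toward the lower number and not beyond the scatter. For compound 3 the estimate is 1300 nM, with an expected range of 500 nM to 3500 nM.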

Compound 3, half-maximal inhibitory concentration: 1120 nM
For compound 3 the middle estimate is 1.2-fold (0.06 log units) above the measured one, within the range that was stated.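

In this assay, methyl in place of hydrogen on a saturated chain carbon, two bonds along the chain from an oxygen next to a carbonyl group, gives a 1.7-fold lower number from compound 2 to compound 3 (0.23 log units; within the scatter), so ethyl and propyl cannot be told apart here. Propyl in place of hydrogen on that oxygen gives an at least 89-fold lower number from compound 1 to compound 3 (1.95 log units; beyond the scatter), large like the ethyl step. This step rests on a limit for compound 1, not a number: the limit of > 100000 nM in this assay, at which 1 of the 3 values shown sits.

As far as these compounds go, whether butyl, a longer chain or a branched chain such as isopropyl would hold this level remains open.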